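The compounds below may be only part of what the source reports. "The series", "measured", "known", "first", "only" and "open" are said of these compounds alone.

Values in a functional assay on HL-60 cells (Homo sapiens) for antiproliferative activity, read by MTT assay, with a stated time of 72 h; a lower number here means a stronger inhibitor, a higher number a weaker inhibitor:
Compound 1 `N=C(NS(=O)(=O)c1ccccc1)N1CCN(c2cc3c(cc2F)c(=O)c(C(=O)O)cn3C2CC2)CC1`: 43 nM
Compound 2 `CCn1cc(C(=O)O)c(=O)c2cc(F)c(N3CCN(C(=N)NS(=O)(=O)c4cccc(Cl)c4)CC3)cc21`: 43 nM
Compound 3 `CCn1cc(C(=O)O)c(=O)c2cc(F)c(N3CCN(C(=N)NS(=O)(=O)c4ccccc4Cl)CC3)cc21`: 43 nM

Compound 1 stands level with compound 2 and compound 3 at the digits reported, so the three values give no ranking. Going by the values given here, no single-place step connects compound 1 to either of the others.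

Compound 4 `N=C(NS(=O)(=O)c1ccc(C(F)(F)F)cc1)N1CCN(c2cc3c(cc2F)c(=O)c(C(=O)O)cn3C2CC2)CC1` is the next analogue to consider. It differs from compound 1 by trifluoromethyl in place of hydrogen on an aromatic carbon, para to a large group, which turns phenyl into 4-(trifluoromethyl)phenyl.

Among the compounds with values here, only one measured step bears on this change, no change at the digits printed from compound 2 to compound 3 (within the scatter). It moves a chlorine on the aryl group attached to the sulfonyl sulfur, and it shows no response to that move. Within the data shown here, it is weak evidence, since it relocates a substituent and does not replace a hydrogen, and no measured step adds a trifluoromethyl. No step beyond the scatter is therefore expected in this assay, and no direction is favoured, though the uncertainty remains wide.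

The expected step is a 1.0-fold higher number from compound 1 to compound 4 (0.02 log units; within the scatter).

For compound 4 the estimated value is 45 nM, with an expected range from 15 nM to 130 nM.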

Compound 4, half-maximal inhibitory concentration: 43 nM
Compound 4: middle estimate off by 1.0-fold (0.02 log units), on the high side; low and high end bracket the measured number.
By their numbers in this assay, from the lowest: compounds 1, 2, 3 and 4 (each within the scatter of the next).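

In this assay, placing trifluoromethyl on an aromatic carbon of the phenyl on the sulfonyl sulfur, para to a large group, gives a direct reading for this change (no change at the digits printed from compound 1 to compound 4 (within the scatter)). The earlier step (no change at the digits printed from compound 2 to compound 3 (within the scatter)) only relocated a chlorine on that aryl group, whereas this one replaces a hydrogen with a larger group, so the read-out at this position is now shown to hold level through an added substituent as well as a moved one, at least for this single para substitution on the cyclopropyl-bearing core of compound 1. No measurement of any property bears on this result, and it supplies no explanation for the level read-out.

The compounds shown leave open whether a group of a different kind at this position, such as an amine, a carboxylic acid or a longer alkyl chain, would give a step beyond the scatter in this assay. They also leave open how the cyclopropyl and ethyl groups on the core compare, as no pair shown differs at that place alone, and whether the aryl group on the sulfonyl sulfur can be replaced by a saturated ring.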